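The source may hold more compounds than are shown below. What is called first, only, known or untested is meant among the compounds shown, and "the series" means these compounds.

Working notes on the series. Compound 3 `CCCc1nc(C)c2cnnc(SC)n12` carries a methylsulfanyl group on the shared core with hydrogen at the position now under study. In a functional assay for inhibition, with Homo sapiens as the target (on this read-out higher numbers stand for weaker inhibition and lower numbers for stronger inhibition), compound 3 reaches only the assay limit of > 48000 nM. Compound 1 `CCCc1nc(C)c2c(-c3ccccc3)nnc(SC)n12` bears a phenyl group in place of that hydrogen. In this assay compound 1 likewise sits at the limit of > 48000 nM. The step that the two limits leave unreadable from compound 1 to compound 3 is therefore not readable, as the limit of > 48000 nM in this assay, at which 2 of the 3 values shown sit, states. Going by the values given here, compound 2 `CCCc1nnc(O)n2c(CCC)nc(C)c12` carries a hydroxy group where compounds 1 and 3 carry methylsulfanyl, and a propyl chain at the position of interest; in this assay compound 2 gives 16000 nM, the only numerical value in the set so far.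

Compound 4 `CCCc1nnc(SC)n2c(CCC)nc(C)c12` is the next target. Relative to compound 3 the change is propyl in place of hydrogen on an aromatic carbon. Among the compounds with values here, no measured step bears directly on this change, since the only neighbouring step from compound 1 to compound 3 is hidden by the limits. Within the data shown here, the one measurable point in the set, compound 2 with its propyl chain, is weak in this assay, and compound 4 differs from it only in the methylsulfanyl group for which no step is known. For compound 4 a value near the limit is expected in this assay, about 40000 nM with a likely range from 12000 nM to 150000 nM. The step of an at least 1.2-fold lower number from compound 3 to compound 4 (0.07 log units; that floor lies within the scatter) is thus estimated as small at best, with a real chance that only a limit is again reported.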

Compound 4, half-maximal inhibitory concentration: > 48000 nM
Compound 4: no number, only a limit; the forecaster's own chance of this, stated with the estimate: 50%; middle value at least 1.2-fold (0.07 log units) from the limit.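

The change of methylsulfanyl in place of hydroxy on an aromatic carbon now has a readable lower bound with propyl held constant: in this assay it is an at least 3.0-fold higher number from compound 2 to compound 4 (0.47 log units; beyond the scatter), so at least within this pair the hydroxy compound gives the lower number. Compound 4 itself reaches only a limit, > 48000 nM. The steps to compound 4 from compound 3 and from compound 1 cannot be read, and with methylsulfanyl on the shared core, hydrogen, phenyl and propyl on this aromatic carbon remain unordered, because all three compounds are held by the same bound: the limit of > 48000 nM in this assay, at which 3 of the 4 values shown sit.

Open is whether the difference between hydroxy and methylsulfanyl also appears with hydrogen or phenyl on this aromatic carbon, as compound 2 is the only hydroxy compound shown and the only one with a numerical value. Also open, on these data alone, is whether an amine in place of methylsulfanyl, or a longer chain in place of propyl on the aromatic carbon, would bring a compound off the limit and give this position a readable step.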